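Working notes: from compound 3 to compound 4

The compounds below may be only part of what the source reports. "The series", "measured", "known", "first", "only" and "open" are said of these compounds alone.

In a functional assay on HCT-116 cells (Homo sapiens) for inhibition, read by MTT assay, with a stated time of 48 h (a lower number here means a stronger inhibitor, a higher number a weaker inhibitor), the measured compounds read as follows:
- compound 1 `COc1cc(-c2nnc(SCc3ccccc3)n2-c2ccc(N(C)C)cc2)cc(OC)c1OC` gives 54000 nM
- compound 2 `COc1ccc(CSc2nnc(-c3cc(OC)c(OC)c(OC)c3)n2-c2ccc(N(C)C)cc2)cc1` gives 1150 nM
- compound 3 `COc1cc(-c2nnc(SCc3ccc(C)cc3)n2-c2ccc(N(C)C)cc2)cc(OC)c1OC` gives > 60000 nM

Compound 3 has no number, only a limit (the limit of > 60000 nM in this assay, at which 1 of the 3 values shown sits). Compound 4 `COc1ccc(C(=O)CSc2nnc(-c3cc(OC)c(OC)c(OC)c3)n2-c2ccc(N(C)C)cc2)cc1O` differs from it at one place, ((3-hydroxy-4-methoxyphenyl)carbonyl in place of 4-methylphenyl on a saturated chain carbon bound to a sulfur), that is, (3-hydroxy-4-methoxyphenyl)carbonyl in place of 4-methylphenyl on a saturated chain carbon bound to a sulfur.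

The measured steps that bear on this all concern the same aromatic ring. Methoxy in place of hydrogen gave a 47-fold lower number from compound 1 to compound 2 (1.67 log units; beyond the scatter), and methyl in place of methoxy gave an at least 52-fold higher number from compound 2 to compound 3 (1.71 log units; beyond the scatter). Methyl in place of hydrogen gave an at least 1.1-fold higher number from compound 1 to compound 3 (0.04 log units; that floor lies within the scatter), so the methyl group of compound 3 shows no measured gain. Compound 4 loses that methyl group and carries a methoxy on its ring, as does compound 2 at 1150 nM in this assay. Within the data shown here, no measured step covers the added carbonyl or hydroxy, so the expectation stays wide.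

A large step to a lower number is expected, namely an at least 30-fold lower number from compound 3 to compound 4 (1.47 log units; beyond the scatter) in the estimate. For compound 4 the estimated value is 2000 nM, with an expected range from 200 nM to 30000 nM.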

Compound 4, half-maximal inhibitory concentration: > 100000 nM
Compound 4: a limit, no number; the forecaster's own chance of this, stated with the estimate: 10%; middle value at least 50-fold (1.69 log units) from the limit.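

In this assay, compound 4 gives only a limit, not a number: the limit of > 100000 nM in this assay, at which 1 of the 4 values shown sits. Set against the 4-methoxyphenyl group, the entering (3-hydroxy-4-methoxyphenyl)carbonyl group gives an at least 86-fold higher number from compound 2 to compound 4 (1.93 log units; beyond the scatter), so a methoxy on the ring does not by itself hold the level of compound 2 once the carbonyl and hydroxy enter, something the earlier compounds, which carried no carbonyl or hydroxy here, could not show. Measured against the phenyl group, the change reads an at least 1.8-fold higher number from compound 1 to compound 4 (0.26 log units; that floor lies within the scatter), and the step from compound 3 to compound 4 cannot be read.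

The compounds shown leave open whether the large step from the 4-methoxyphenyl compound goes with the carbonyl or with the hydroxy, the two entering together in a single change. Also open, as far as these compounds go, is how this position responds to a group of another kind, such as an amine, a carboxylic acid or a longer chain, on the saturated chain carbon bound to a sulfur.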